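This account rests on a few compounds, and the source may have more. Where it says the series, first, only, none or still open, it means among the compounds named here.

The set comprises compound 1 `O=[N+]([O-])c1ccccc1CNc1cc(C(F)(F)F)cc2[nH]ncc12`, compound 2 `O=[N+]([O-])c1ccc(O)cc1CNc1cc(Br)cc2[nH]ncc12`, compound 3 `FC(F)(F)c1cc(NC[C@H]2CCCN2)c2cn[nH]c2c1` and the as yet unmeasured compound 4 `FC(F)(F)c1cc(NC[C@@H]2CCCCN2)c2cn[nH]c2c1`. In a functional assay on H22 cells (Mus musculus) for inhibition, read by MTT assay, with a stated time of 24 h (a lower number here means a stronger inhibitor, a higher number a weaker inhibitor), compound 1 gives 9010 nM. Compound 2 reaches only a limit in this assay, > 20000 nM, and no number. the limit of > 20000 nM in this assay, at which 1 of the 3 values shown sits. In this assay compound 3 gives 19700 nM, the highest of the two numbers measured; the nearest is compound 1, whose number is lower by a margin beyond the usual scatter. Compound 4 differs from compound 3 in one place: piperidin-2-yl in place of pyrrolidin-2-yl on a saturated chain carbon bound to a nitrogen on an aromatic ring. No measured pair among these compounds shows a step of this kind, so the values shown say nothing about how it should read. The expected step is therefore a 1.0-fold higher number from compound 3 to compound 4 (0.01 log units; within the scatter) in this assay, none beyond the scatter. For compound 4 the estimate in this assay is 20000 nM, with a range from 8000 nM to 50000 nM. Given that compound 3 gives 19700 nM, this assay may well return no number at all for compound 4.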

Compound 4, half-maximal inhibitory concentration: 21700 nM
Compound 4: the middle estimate sits 1.1-fold (0.04 log units) below what was measured; the measured number falls inside the stated range.
By their numbers in this assay, from the lowest: compound 1; then compounds 3 and 4 (each within the scatter of the next).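

Among the compounds shown here, the step from the pyrrolidin-2-yl to the piperidin-2-yl ring, on a saturated chain carbon bound to a nitrogen on an aromatic ring, is the first readable change at this place, and in this assay it leaves the reading where it was: a 1.1-fold higher number from compound 3 to compound 4 (0.04 log units; within the scatter). Compound 4 also returns a number and not a limit, so swapping the five-membered ring for the six-membered one does not move the reading out of the range that this assay can report. Compound 2 remains the only compound shown that reaches a limit and no number: the limit of > 20000 nM in this assay, at which 1 of the 4 values shown sits.

As far as these compounds go, whether any group at this place can give a clearly stronger inhibitor stays open. Neither an open-chain amine nor a morpholine ring stands among these compounds, and the opposite configuration of either ring is also absent.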